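This account rests on a few compounds, and the source may have more. Where it says the series, first, only, none or still open, it means among the compounds named here.

Going by the values given here, in an assay on CHO cells for displacement of a labelled ligand from prostaglandin E2 receptor EP1 subtype (Mus musculus), read by scintillation counting (on this read-out higher numbers stand for weaker inhibition and lower numbers for stronger inhibition), compound 1 `O=C(O)/C=C/c1ccc(Cn2cccn2)cc1OCCc1ccc2ccccc2c1` gives 2900 nM, the only plain number among the three compounds measured so far. For compound 2 `O=C(O)/C=C/c1ccc(Cc2ccccc2)cc1OCCc1ccc2ccccc2c1` the assay reports only a limit, > 10000 nM. For compound 3 `O=C(O)/C=C/c1ccc(OCc2ccccc2)cc1OCCc1ccc2ccccc2c1` it likewise reports only a limit, > 10000 nM. The step of an at least 3.4-fold higher number from compound 1 to compound 2 (0.53 log units; beyond the scatter) and the step of an at least 3.4-fold higher number from compound 1 to compound 3 (0.53 log units; beyond the scatter) each end at the limit of > 10000 nM in this assay, at which 2 of the 3 values shown sit, and each alters the (1H-pyrazol-1-yl)methyl group. Compound 4 `O=C(O)CCCc1ccc(Cn2cccn2)cc1OCCc1ccc2ccccc2c1` differs from compound 1 elsewhere: 3-carboxypropyl in place of 2-carboxyethenyl on an aromatic carbon. Among the compounds with values here, no measured step touches this part of the core of compound 1, so the measured steps give no direct guide to the change. The change is expected to bring a 1.6-fold higher number from compound 1 to compound 4 (0.19 log units; within the scatter), and compound 4 is estimated at 4500 nM with a range from 1500 nM to 12000 nM in this assay.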

Compound 4, inhibition constant: 4000 nM
Estimate against measurement, compound 4: 1.1-fold (0.05 log units) above, within the range that was stated.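

At this position on the shared core, 3-carboxypropyl in place of 2-carboxyethenyl gives a 1.4-fold higher number from compound 1 to compound 4 (0.14 log units; within the scatter) in this assay. The saturated chain therefore serves as well as the unsaturated one here, and unlike the two changes to the (1H-pyrazol-1-yl)methyl group, this change yields a plain number instead of a limit. Nothing given here bears on why the two chains read alike. The compounds shown leave open whether a longer chain, a shorter chain, or an amide or tetrazole in place of the carboxylic acid would keep this reading.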